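The compounds below may be only part of what the source reports. "The series", "measured", "known", "first", "only" and "open" are said of these compounds alone.

Compound 1, `CCCCCCCCCCCCCCCCCC(=O)OCC1CN(C(=O)c2cc(OC)c(OC)c(OC)c2)CCN1C(=O)c1cc(OC)c(OC)c(OC)c1`: 45000 nM
Compound 2, `COc1cc(C(=O)N2CCN(C(=O)c3cc(OC)c(OC)c(OC)c3)C(COC(=O)C3CCCCC3)C2)cc(OC)c1OC`: 290 nM

Of the compounds shown here, two built on a shared core have been measured in a functional assay (Oryctolagus cuniculus) for inhibition of platelet-activating factor receptor (Cavia porcellus); a higher number here means a weaker inhibitor, a lower number a stronger inhibitor. In this assay compound 1 gives 45000 nM, whereas compound 2 gives 290 nM. Within the data shown here, compound 2 thus stands at the lowest of the two numbers; its only neighbour, compound 1, sits at a far higher number, a gap well beyond the scatter of this assay.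

Compound 3, `CCC(CC)NC(=O)OCC1CN(C(=O)c2cc(OC)c(OC)c(OC)c2)CCN1C(=O)c1cc(OC)c(OC)c(OC)c1`, has not yet been measured. It differs from compound 2 in a single place: (pentan-3-yl)amino in place of cyclohexyl on a carbonyl carbon. A ring-bearing group gives way to a chain-like one carrying a hydrogen-bond donor, while the carbonyl carbon and the oxygen next to a carbonyl group are kept. Among the measured compounds shown here, no measured pair shows an exchange of this kind, so the size of the step cannot be read from the data. The step of a 1.2-fold higher number from compound 2 to compound 3 (0.08 log units; within the scatter) is expected to lie within the scatter or only modestly beyond it, with no clear direction. Compound 3 is estimated at 350 nM, with a range from 90 nM to 1400 nM.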

Compound 3, half-maximal inhibitory concentration: 130 nM
For compound 3 the middle estimate is 2.7-fold (0.43 log units) above the measured one; the measured number falls inside the stated range.
By their numbers in this assay, from the lowest: compound 3; then compound 2; then compound 1.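

In this assay, putting (pentan-3-yl)amino in place of cyclohexyl on a carbonyl carbon gives a 2.2-fold lower number from compound 2 to compound 3 (0.35 log units; beyond the scatter) and so moves the number modestly but measurably downward. This shows that the six-membered ring of carbon is not needed at this position to reach a number in this range: a group with no ring, carrying a hydrogen-bond donor and with the same count of heavy atoms, gives the lower number of the two. Nothing shown here accounts for this step.

The exchange alters two things at once, removing the ring and bringing in the nitrogen with its hydrogen, and compound 2 and compound 3 alone cannot tell these two changes apart: a cyclohexylamino group on the same carbonyl carbon would keep the ring together with the nitrogen, whereas a pentan-3-yl group would keep the open chain without it. On these data alone, how much size this position accepts on the nitrogen also remains open, for instance with a smaller propan-2-ylamino group or a longer nonan-5-ylamino group.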